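Biaryl replacement on the core: expected solubility of compound 4

The source may hold more compounds than are shown below. What is called first, only, known or untested is meant among the compounds shown, and "the series" means these compounds.

Of the compounds shown here, three sharing one core have been measured in a physicochemical assay for solubility, with a stated time of 18 h, at pH 7.4; a lower number here means a less soluble compound, a higher number a more soluble compound. Compound 1 `COc1cccc(CNCCCNc2ccnc3cc(Oc4ccc(F)cc4)ccc23)c1O` gives 14500 nM. Compound 2 `COc1cccc(CNCCCNc2ccnc3cc(Cc4ccc(C#N)cc4)ccc23)c1O` gives 4200 nM. Compound 3 `COc1cccc(CNCCCNc2ccnc3cc(Oc4cccc(N(C)C)c4)ccc23)c1O` gives 14500 nM. Compound 3 stands level with compound 1 at the digits printed, the two together being the highest of the three numbers, while compound 2 is the furthest from it: a 3.5-fold higher number from compound 2 to compound 3 (0.54 log units; beyond the scatter). The step of no change at the digits printed from compound 1 to compound 3 (within the scatter) shows that exchanging one substituted phenyl for another on the ring oxygen left the number where it was.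

Compound 4 `COc1cccc(CNCCCNc2ccnc3cc(-c4ccc(C(C)(C)C)cc4)ccc23)c1O` is not yet measured in this assay. It differs from compound 3 as follows: 4-(tert-butyl)phenyl in place of 3-(dimethylamino)phenoxy on an aromatic carbon. The step that bears most closely on this is a 3.5-fold lower number from compound 1 to compound 2 (0.54 log units; beyond the scatter), where the phenoxy link was likewise replaced by a carbon-attached aryl group and the number fell by a modest amount. The change to compound 4 goes further, since the entering group carries none of the hydrogen-bond acceptors that the leaving group had. Among the measured compounds shown here, a downward step in this assay is therefore expected, somewhat larger than the one from compound 1 to compound 2. For compound 4 the expected step is a 7.3-fold lower number from compound 3 to compound 4 (0.86 log units; beyond the scatter). For compound 4 the estimate is 2000 nM, within a range of 500 nM to 8000 nM.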

Compound 4, solubility: 32000 nM
The estimate for compound 4 lay 16-fold (1.20 log units) below the measured number; measured number above the stated range.
By their numbers in this assay, from the lowest: compound 2; then compounds 1 and 3 (each within the scatter of the next); then compound 4.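

In this assay the 4-(tert-butyl)phenyl group sits highest of the four compounds, with a 2.2-fold higher number from compound 3 to compound 4 (0.34 log units; beyond the scatter) and a 2.2-fold higher number from compound 1 to compound 4 (0.34 log units; beyond the scatter) and also a 7.6-fold higher number from compound 2 to compound 4 (0.88 log units; beyond the scatter) as its steps. At this aromatic carbon, an entering group of carbon only, replacing a phenoxy group that holds nitrogen and oxygen, therefore goes with a rise rather than a fall, so the hydrogen-bond acceptor counts printed for compound 3 and compound 4 do not order these two numbers. Replacing the phenoxy link does not fix the direction either, as the 4-cyanobenzyl group of compound 2 stands lowest and the directly attached aryl group of compound 4 highest, and no supporting measurement is available to account for the rise.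

The compounds shown do not separate the contribution of the direct attachment of the aryl ring from that of the tert-butyl group. An unsubstituted phenyl at the same aromatic carbon would divide those two contributions, and a 4-carboxyphenyl or 4-morpholinophenyl group there would test how far the higher number holds when the tert-butyl group is exchanged.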